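Substituent swap on the aryl urea: chloro, trifluoromethyl, nitro

The compounds below may be only part of what the source reports. "The series", "measured", "known", "first", "only" and "open" are said of these compounds alone.

Compound 1, `Cc1cc(NC(=O)Nc2cccc(Cl)c2)c2ccccc2n1`: in an ADME assay on Raji cells (Homo sapiens) for cytotoxicity, with a stated time of 72 h (a lower number here means that less compound is needed, a higher number that more compound is needed for the effect), compound 1 gives 18000 nM.
Compound 2, `Cc1cc(NC(=O)Nc2cccc(C(F)(F)F)c2)c2ccccc2n1`: in this assay compound 2 gives 10000 nM.

Compound 2 and compound 1 share the same core and the same urea; they differ only in the group on the outer ring. The two numbers are within the usual scatter of each other: the step of a 1.8-fold lower number from compound 1 to compound 2 (0.26 log units; within the scatter) does not separate them, so neither compound can be called the more or less potent of the pair.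

Compound 3, `Cc1cc(NC(=O)Nc2cccc([N+](=O)[O-])c2)c2ccccc2n1`, keeps everything of compound 2 except that group: nitro in place of trifluoromethyl on an aromatic carbon. Among the compounds with values here, the only step so far at this place is the step of a 1.8-fold lower number from compound 1 to compound 2 (0.26 log units; within the scatter), which stayed within the scatter. On that single precedent, no step beyond the scatter is expected in this assay; the direction cannot be read from the data.

Compound 3 is therefore estimated at 12000 nM, in a range of 5000 nM to 30000 nM, which means an expected step of a 1.2-fold higher number from compound 2 to compound 3 (0.08 log units; within the scatter).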

Compound 3, half-maximal effective concentration: > 25000 nM
Compound 3 ended at the assay's limit; the forecaster's own chance of this, stated with the estimate: 5%; middle value at least 2.0-fold (0.31 log units) from the limit.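

In this assay compound 3 gives > 25000 nM, which is a limit of the assay and not a number: the limit of > 25000 nM in this assay, at which 1 of the 3 values shown sits.

Within the data shown here, this place on the outer ring is not indifferent to the group it carries, since the swap of trifluoromethyl for nitro gives an at least 2.5-fold higher number from compound 2 to compound 3 (0.39 log units; beyond the scatter), whereas the only earlier step here, a 1.8-fold lower number from compound 1 to compound 2 (0.26 log units; within the scatter), did not separate its two compounds. The second new step, an at least 1.3-fold higher number from compound 1 to compound 3 (0.14 log units; that floor lies within the scatter), gives only a floor, so the data do not rank nitro against chloro at this place, and only the trifluoromethyl to nitro change is resolved, with its true size unknown.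

On these data alone, with three compounds, it remains open whether the change in this assay follows from the hydrogen-bond acceptors that nitro brings or from something else about the group. As far as these compounds go, how an amine or a carboxylic acid on the same aromatic carbon would read also remains open, as does the effect of any of these groups at another place on the ring.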